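Fluoro on the phenyl ring of a weak aorta inhibitor

This account rests on a few compounds, and the source may have more. Where it says the series, first, only, none or still open, it means among the compounds named here.

Measured so far:
Compound 1, `COc1nc(-c2nc3ccccc3n2C)cc(-c2ccccc2)c1C#N`: 300000 nM
Compound 2, `CCOc1nc(-c2nc3ccccc3n2C)cc(-c2ccccc2)c1C#N`: 364000 nM
Compound 3, `COc1nc(-c2nc3ccccc3[nH]2)cc(-c2ccc(Cl)cc2)c1C#N`: 286000 nM

All three compounds share one core and are weak in a functional assay on aorta (Rattus norvegicus, strain Wister); on this read-out lower numbers stand for stronger inhibition and higher numbers for weaker inhibition. Compound 2 has the highest of the three numbers, yet its distance to compound 1 and to compound 3 is within the scatter, so the three cannot be ranked. For the measured compounds named here, the only single-site step, a 1.2-fold higher number from compound 1 to compound 2 (0.08 log units; within the scatter), is small and tells that lengthening the alkoxy chain changes nothing beyond the scatter.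

Compound 4, `CCOc1nc(-c2nc3ccccc3n2C)cc(-c2ccc(F)cc2)c1C#N`, is compound 2 with fluoro in place of hydrogen on an aromatic carbon; cut one bond further out, the change reads phenyl to 4-fluorophenyl. Going by the values given here, no measured pair isolates a substituent on this ring: compound 3 carries a chloro there but also differs from compound 1 at the benzimidazole nitrogen, and its value lies within the scatter of both compounds 1 and 2. The step from compound 1 to compound 2 does not touch the phenyl ring either. With nothing pointing either way, no shift beyond the scatter is expected, and the estimated step is a 1.1-fold lower number from compound 2 to compound 4 (0.03 log units; within the scatter). For compound 4 the expected value in this assay is 340000 nM, with a range from 150000 nM to 750000 nM.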

Compound 4, half-maximal inhibitory concentration: 362000 nM
For compound 4 the middle estimate is 1.1-fold (0.03 log units) below the measured one, within the range that was stated.
By their numbers in this assay, from the lowest: compounds 3, 1, 4 and 2 (each within the scatter of the next).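

In this assay the change from phenyl to 4-fluorophenyl gives a 1.0-fold lower number from compound 2 to compound 4 (0.00 log units; within the scatter) and is the first step shown that touches this ring in one place alone. Compound 3 also carries a substituent on this ring, but it differs from the other compounds elsewhere too, so it could not isolate the ring's contribution. Here, a single fluoro on an aromatic carbon, para to a large group, leaves the number within the scatter on an already weak compound, and no further data bear on this result.

As far as these compounds go, whether an amine or a carboxylic acid at this place would move the number beyond the scatter remains open. So does the outcome of putting a fluoro at another carbon of this ring, and no step shown so far reaches beyond the scatter.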